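This account rests on a few compounds, and the source may have more. Where it says the series, first, only, none or still open, it means among the compounds named here.

Measured so far:

- compound 1 `O=C(CCCc1ccccc1)N[C@H]1CCOC1=O` — in a functional assay on NCI-H630 cells (Homo sapiens) for cytotoxicity, read by sulforhodamine B assay, with a stated time of 5 days (on this read-out higher numbers stand for weaker inhibition and lower numbers for stronger inhibition), compound 1 gives > 100000 nM, a limit of the assay rather than a number.
- compound 2 `O=C(CCCCCc1ccccc1)N[C@H]1CCOC1=O` — compound 2 gives > 100000 nM, again a limit of the assay.
- compound 3 `O=C(CCCc1ccccc1)CC(=O)N[C@H]1CCOC1=O` — compound 3 gives > 100000 nM, also a limit of the assay.

For the measured compounds named here, compound 2 therefore cannot be placed relative to the others: every value in this assay is a limit, as the limit of > 100000 nM in this assay, at which 3 of the 3 values shown sit, records, and no step between measured compounds can be computed. Going by the values given here, nothing so far separates one chain length or one linker from another.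

The next compound is compound 4 `O=C(CCCCCCc1ccccc1)N[C@H]1CCOC1=O`, which is to be measured in this assay. It differs from compound 2 by benzyl in place of phenyl on a saturated chain carbon, five bonds along the chain from a carbonyl carbon — one more saturated carbon between the carbonyl and the aromatic ring.

With compound 1 and compound 2 both at the limit, lengthening the chain has shown no effect that the assay can register, and compound 3, with a different linker, sits at the same limit. The expectation for the step from compound 2 to compound 4 is therefore no change beyond the scatter, a step that the limit leaves unreadable from compound 2 to compound 4, with the most likely outcome being another limit. Compound 4 is estimated at 150000 nM, within a range from 60000 nM to 400000 nM.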

Compound 4, half-maximal inhibitory concentration: > 100000 nM
Compound 4 was reported as a limit (the forecaster's own chance of this, stated with the estimate: 85%); the middle value is on the limit's open side.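

Compound 2 and compound 4 are both reported only as limits, so no step between them can be read: the limit of > 100000 nM in this assay, at which 4 of the 4 values shown sit.

The compounds shown leave open whether any chain length or linker in this series would give a value inside the measurable range, and how the four compounds rank against one another.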